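The source may hold more compounds than are shown below. What is called first, only, known or untested is meant among the compounds shown, and "the series" means these compounds.

Measured so far in a functional assay on A549 cells (Homo sapiens) for antiproliferative activity, read by MTT assay, with a stated time of 48 h; a higher number here means a weaker inhibitor, a lower number a stronger inhibitor:
Compound 1 `N#CC1=C(N)Oc2c(N)cc3nc4ccccc4nc3c2C12C(=O)N(Cc1cnnn1-c1ccc(F)cc1)c1ccccc12` — a limit of this assay, > 50000 nM
Compound 2 `Cc1ccc(C)c(-n2nncc2CN2C(=O)C3(C(C#N)=C(N)Oc4c(N)cc5nc6ccccc6nc5c43)c3ccccc32)c1` — a limit of this assay, > 50000 nM
Compound 3 `CCc1cccc(CC)c1-n1nncc1CN1C(=O)C2(C(C#N)=C(N)Oc3c(N)cc4nc5ccccc5nc4c32)c2ccccc21` — a limit of this assay, > 50000 nM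

Compound 3 therefore stands at the edge of what this assay can report, and not at a number. The three compounds share one core and differ only in the group on an aromatic nitrogen. The steps between them, a step that the two limits leave unreadable from compound 1 to compound 2, a step that the two limits leave unreadable from compound 1 to compound 3 and a step that the two limits leave unreadable from compound 2 to compound 3, cannot be read, because of the limit of > 50000 nM in this assay, at which 3 of the 3 values shown sit.

Compound 4 `N#CC1=C(N)Oc2c(N)cc3nc4ccccc4nc3c2C12C(=O)N(Cc1cnnn1-c1ccc([N+](=O)[O-])cc1[N+](=O)[O-])c1ccccc12` is not yet measured. It differs from compound 3 in one place: 2,4-dinitrophenyl in place of 2,6-diethylphenyl on an aromatic nitrogen. The three measured steps are all exchanges of the group on this same nitrogen, and none of them produced a readable change, so they give no direction for the new step. The expectation for compound 4 is that it also returns a limit rather than a number, and the step is estimated as a step that the limit leaves unreadable from compound 3 to compound 4, meaning no change beyond the scatter. Compound 4 is estimated at 60000 nM, with a range from 20000 nM to 200000 nM.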

Compound 4, half-maximal inhibitory concentration: > 50000 nM
Compound 4: no number, only a limit; the forecaster's own chance of this, stated with the estimate: 80%; the middle value is on the limit's open side.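

In this assay, within the data shown here, no step between compound 4 and compound 1, compound 2 or compound 3 can be read, because all four compounds return a limit and not a number: the limit of > 50000 nM in this assay, at which 4 of the 4 values shown sit.

The compounds shown leave open whether any other group on this aromatic nitrogen, or any change to the shared core, would give a number in this assay at all.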